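Oxime ether side chains on a shared indolinone core

The compounds below may be only part of what the source reports. "The series", "measured", "known", "first", "only" and "open" are said of these compounds alone.

Compound 1 `CN1CCCCC1CCO/N=C1C(=C2/C(=O)Nc3ccccc32)/Cc2ccccc2/1`: 163 nM
Compound 2 `CN1CCCC1CCO/N=C1C(=C2/C(=O)Nc3ccccc32)/Nc2ccccc2/1`: 18.7 nM

In an assay on HEK293T cells for binding affinity to serine/threonine-protein kinase tousled-like 2 (Homo sapiens), read by FRET (on this read-out higher numbers stand for weaker inhibition and lower numbers for stronger inhibition), compound 2 gives the lower of the two numbers, and compound 1 gives a number beyond the usual scatter above it. Compound 3 `CN1CCC(O/N=C2C(=C3/C(=O)Nc4ccccc43)/Nc3ccccc3/2)CC1` differs from compound 2 by 1-methylpiperidin-4-yl in place of 2-(1-methylpyrrolidin-2-yl)ethyl on an oxygen. Within the data shown here, no step between measured compounds isolates this change, so its size is uncertain; a small move, within or just beyond the scatter, is expected in either direction. Compound 3 is therefore estimated at 30 nM (range 8 nM to 120 nM), meaning an expected step of a 1.6-fold higher number from compound 2 to compound 3 (0.21 log units; within the scatter).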

Compound 3, half-maximal inhibitory concentration: 33.2 nM
Compound 3: the middle estimate sits 1.1-fold (0.04 log units) below what was measured; the range from low to high includes it.
By their numbers in this assay, from the lowest: compounds 2 and 3 (each within the scatter of the next); then compound 1.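

In this assay, putting 1-methylpiperidin-4-yl in place of 2-(1-methylpyrrolidin-2-yl)ethyl on the oxygen gives a 1.8-fold higher number from compound 2 to compound 3 (0.25 log units; within the scatter). This position therefore accepts two different ring-bearing side chains, a six-membered and a five-membered ring, and this read-out does not tell them apart. No available evidence accounts for this result.

Both side chains carry a ring with one nitrogen atom. On these data alone, it remains open how a morpholine ring, or a plain methyl group, on the same oxygen would read in this assay.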